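The source may report more compounds than this note shows. Statements on the series, on what has been measured and on what is new or still open speak of the compounds shown alone.

Measured so far in a functional assay on A549 cells (Homo sapiens) for antiproliferative activity, read by MTT assay; on this read-out higher numbers stand for weaker inhibition and lower numbers for stronger inhibition:
compound 1 `COc1cc2ncnc(NCc3cccc(NC(=O)Nc4ccccc4)c3)c2cc1OC` gives 17100 nM
compound 2 `COc1cc2ncnc(NCc3cccc(NC(=O)Nc4cccc(C)c4)c3)c2cc1OC` gives 27100 nM
compound 3 `COc1cc2ncnc(NCc3cccc(NC(=O)Nc4ccc(C)cc4)c3)c2cc1OC` gives 12900 nM

Compound 3 holds the lowest of the three numbers; its gap to compound 1 is within the scatter, and only a 2.1-fold lower number from compound 2 to compound 3 (0.32 log units; beyond the scatter) is beyond it. Compound 4 `COc1cc2ncnc(NCc3cccc(NC(=O)Nc4ccc(C(C)(C)C)cc4)c3)c2cc1OC` differs from compound 3 by tert-butyl in place of methyl on an aromatic carbon. Going by the values given here, the steps that bear on it are the two methyl additions, a 1.6-fold higher number from compound 1 to compound 2 (0.20 log units; within the scatter) and a 1.3-fold lower number from compound 1 to compound 3 (0.12 log units; within the scatter), both within the scatter, and the modest 2.1-fold lower number from compound 2 to compound 3 (0.32 log units; beyond the scatter). Nothing measured covers a group larger than methyl at that position, so no step beyond the scatter is expected in this assay. Compound 4 is therefore expected near 11000 nM, between 4000 nM and 30000 nM, a step of a 1.2-fold lower number from compound 3 to compound 4 (0.07 log units; within the scatter).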

Compound 4, half-maximal inhibitory concentration: 5210 nM
Estimate against measurement, compound 4: 2.1-fold (0.32 log units) above, and the stated range covers the measured number.
By their numbers in this assay, from the lowest: compound 4; then compounds 3, 1 and 2 (each within the scatter of the next, the first and the last beyond it).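

In this assay, the aromatic carbon para to a large group proves responsive to group size: methyl alone left the number within the scatter of the unsubstituted compound, whereas tert-butyl gives a 3.3-fold lower number from compound 1 to compound 4 (0.52 log units; beyond the scatter) and a 2.5-fold lower number from compound 3 to compound 4 (0.39 log units; beyond the scatter). The largest separation in the series is now a 5.2-fold lower number from compound 2 to compound 4 (0.72 log units; beyond the scatter), a step that changes both the group and its place on the ring. No supporting data bear on why the larger group lowers the number.

Open, as far as these compounds go, is whether this extends beyond alkyl groups at this carbon, for example to a methoxy group, an amine or a carboxylic acid. Also open, from the compounds shown here alone, is how tert-butyl behaves at the carbon bearing methyl in compound 2.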